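Chloro for Fluoro on the Anilino Ring of Compound 3

The compounds below may be only part of what the source reports. "The series", "measured", "known", "first", "only" and "open" are said of these compounds alone.

Compound 3, `O=C(/C=C\Nc1ccc(F)cc1)c1cn(-c2ccccc2)nc1-c1ccc(Cl)cc1`, gives in a functional assay on PC-3 cells (Homo sapiens) for antiproliferative activity, read by MTT assay, with a stated time of 48 h (a lower number here means a stronger inhibitor, a higher number a weaker inhibitor), only a limit, > 50000 nM. Its two neighbours in this set carry a chloro group on the anilino ring instead: compound 1, `O=C(/C=C\Nc1ccc(Cl)cc1)c1cn(-c2ccccc2)nc1-c1ccccc1`, gives 5200 nM, and compound 2, `O=C(/C=C\Nc1ccc(Cl)cc1)c1cn(-c2ccccc2)nc1-c1ccc(F)cc1`, gives 3800 nM. Among the compounds with values here, the one measured step, a 1.4-fold lower number from compound 1 to compound 2 (0.14 log units; within the scatter), concerns a different position and does not speak directly to the change at hand. Compound 4, `O=C(/C=C\Nc1ccc(Cl)cc1)c1cn(-c2ccccc2)nc1-c1ccc(Cl)cc1`, differs from compound 3 by chloro in place of fluoro on an aromatic carbon. Within the data shown here, no measured step covers this change; what the set shows is that compound 1 and compound 2, each with a (4-chlorophenyl)amino group, return numbers, whereas compound 3, with the (4-fluorophenyl)amino group, sits at the limit described under (the limit of > 50000 nM in this assay, at which 1 of the 3 values shown sits). He therefore expects a number for compound 4 rather than a limit, with a step of an at least 5.5-fold lower number from compound 3 to compound 4 (0.74 log units; beyond the scatter) toward a stronger inhibitor, while allowing that the assay might again report only a limit. His estimate for compound 4 in this assay is 9000 nM, within 2500 nM to 50000 nM.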

Compound 4, half-maximal inhibitory concentration: 3890 nM
The estimate for compound 4 lay 2.3-fold (0.36 log units) above the measured number; the measured number falls inside the stated range.
By their numbers in this assay, from the lowest: compounds 2, 4 and 1 (each within the scatter of the next). At a limit, above all of these: compound 3.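

In this assay, within the data shown here, chloro in place of fluoro on the anilino ring gives an at least 12-fold lower number from compound 3 to compound 4 (1.10 log units; beyond the scatter), the first single change in the set to produce a step beyond the scatter, and it places this site, para to a large group, among the changes that matter here. On the other aromatic ring, with chloro fixed on the anilino ring, the same exchange gives a 1.0-fold higher number from compound 2 to compound 4 (0.01 log units; within the scatter), and chloro in place of hydrogen gives a 1.3-fold lower number from compound 1 to compound 4 (0.13 log units; within the scatter), so hydrogen, fluoro and chloro at that second site cannot be told apart. Compound 3 stays a limit and not a number, the only one among the compounds shown: the limit of > 50000 nM in this assay, at which 1 of the 4 values shown sits.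

Compound 3 is the only compound shown with the (4-fluorophenyl)amino group, so it stays open whether that group also ends at a limit with hydrogen or fluoro on the other ring. On these data alone, how bromo, methyl, methoxy or an amine would read on the anilino ring also stays open.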